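Swapping a hydroxycyclohexyl ether for a nitrophenyl ether

The compounds below may be only part of what the source reports. "The series", "measured", "known", "first", "only" and "open" are said of these compounds alone.

Compound 1 `O=S(=O)(NCCNC(=S)Nc1cc(C(F)(F)F)cc(C(F)(F)F)c1)c1ccc(-c2ccccc2O[C@H]2CC[C@@H](O)CC2)s1`: 10900 nM
Compound 2 `COc1ccc(Oc2ccc(C(C)C)cc2-c2ccsc2S(=O)(=O)NCCNC(=S)Nc2cc(C(F)(F)F)cc(C(F)(F)F)c2)cc1OC`: 8300 nM

In a functional assay on HeLa cells (Homo sapiens) for inhibition, read by CCK-8 assay, with a stated time of 48 h (a lower number here means a stronger inhibitor, a higher number a weaker inhibitor), compound 1 gives 10900 nM and compound 2 gives 8300 nM. For the measured compounds named here, these two numbers lie within the usual scatter of each other, so compound 1 stands level with the only other compound measured. The next compound to be tested is compound 3 `O=[N+]([O-])c1ccc(Oc2ccccc2-c2ccc(S(=O)(=O)NCCNC(=S)Nc3cc(C(F)(F)F)cc(C(F)(F)F)c3)s2)cc1`, which has 4-nitrophenyl in place of 4-hydroxycyclohexyl on an oxygen on an aromatic ring. Going by the values given here, no measured step shows what this exchange does, so the expectation is a cautious one. The shared core is unchanged, and only a modest move towards a stronger inhibitor in this assay is anticipated. The estimated step is a 1.8-fold lower number from compound 1 to compound 3 (0.26 log units; within the scatter), and it may not clear the scatter. For compound 3 the expected value is 6000 nM, with an estimated range from 2000 nM to 18000 nM.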

Compound 3, half-maximal inhibitory concentration: 9900 nM
Estimate against measurement, compound 3: 1.7-fold (0.22 log units) below; the measured number falls inside the stated range.
By their numbers in this assay, from the lowest: compounds 2, 3 and 1 (each within the scatter of the next).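

For the compounds shown here, on an oxygen on an aromatic ring, the exchange of 4-hydroxycyclohexyl for 4-nitrophenyl gives the first direct reading of a change at this position: in this assay, the step is a 1.1-fold lower number from compound 1 to compound 3 (0.04 log units; within the scatter). A non-aromatic ring with two defined stereocentres can thus give way to an aromatic ring carrying a nitro group, with no difference that can be told from the scatter. No measured evidence bears on the reason for this result.

One exchange cannot show whether this position is insensitive in general, and a 4-aminophenyl or 4-carboxyphenyl group on the same oxygen might read differently. As far as these compounds go, whether a ring is needed there at all also stays open, and a plain methyl or a longer alkyl chain in its place would address that question.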